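This account rests on a few compounds, and the source may have more. Where it says the series, first, only, none or still open, it means among the compounds named here.

Compound 1 `Cc1cc(C(F)(F)F)cc(NC[C@@H]2CC3(CC3)CN2C(=O)c2nc(C)sc2-c2ccccc2)n1` was tested in a functional assay on CHO cells for antagonist activity at Orexin/Hypocretin receptor type 1 (Homo sapiens), read by FLIPR and calcium flux (a higher number here means a more potent compound, by a factor of ten per unit of this negative logarithm, a lower number a less potent compound), where compound 1 gives 7.8. Of the two compounds measured in this assay it stands lower; the other, compound 2 `Cc1ccc(-c2ncccn2)c(C(=O)N2CC3(CC3)C[C@H]2CNc2ccc(C(F)(F)F)cn2)n1`, shares the amine and the spirocyclic ring of compound 1 but carries a different aryl amide and a different pyridinyl group, and in this assay compound 2 gives 8.4, a gap that lies beyond the usual scatter. Among the compounds with values here, since compound 2 differs from compound 1 in more than one place, no single step can be drawn between them, and the two numbers can only be set side by side.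

Compound 3 `Cc1nc(C(=O)N2CC3(CC3)C[C@H]2CNc2ccc(Cl)cn2)c(-c2ccccc2)s1` keeps the core of compound 1 and changes only the group on the amine: 5-chloropyridin-2-yl in place of 6-methyl-4-(trifluoromethyl)pyridin-2-yl on an amine nitrogen. Within the data shown here, no measured pair separates this change from others, so its effect is not known from the numbers at hand. The step from compound 1 to compound 3 in this assay is expected to be small, as a number 0.10 log units higher from compound 1 to compound 3 (within the scatter), not beyond the scatter in either direction. In this assay compound 3 is therefore estimated at 7.9, with a range from 7.3 to 8.5.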

Compound 3, negative logarithm of the antagonist equilibrium constant: 8.3
Compound 3: middle estimate off by 0.40 log units, on the low side; the measured number falls inside the stated range.
By their numbers in this assay, from the lowest: compound 1; then compounds 3 and 2 (each within the scatter of the next).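

In this assay, within the data shown here, replacing 6-methyl-4-(trifluoromethyl)pyridin-2-yl with 5-chloropyridin-2-yl on an amine nitrogen gives a number 0.50 log units higher from compound 1 to compound 3 (beyond the scatter), the first step here that isolates a single place in the molecule. It shows that this position is sensitive to the substituents on the pyridine and that the group with fewer heavy atoms is not a loss at this position, even though the ring type and the counts of hydrogen-bond donors and acceptors stay the same. Nothing measured here explains the size or direction of this step.

The step changes the methyl, the trifluoromethyl and the chlorine together, so the share of each in the result stays unresolved. From the compounds shown here alone, how an unsubstituted pyridin-2-yl or a 5-fluoropyridin-2-yl would compare on this amine nitrogen remains open, as does whether the same step would hold with a different aryl amide on the core.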